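Trading a branched chain for a short unsaturated one

The source may hold more compounds than are shown below. What is called first, only, known or untested is meant among the compounds shown, and "the series" means these compounds.

Measured compounds:
Compound 1, `C=CCCCn1c(Cc2cc(OC)c(OC)c(OC)c2)nc2c(N)nc(F)nc21`: 44700 nM
Compound 2, `CCC(CC)Cn1c(Cc2cc(OC)c(OC)c(OC)c2)nc2c(N)ncnc21`: 158000 nM

Two compounds share a core and a trimethoxy-substituted benzyl group, differing in the chain on the aromatic nitrogen and in one substituent on the core. In a functional assay on MCF7 cells (Homo sapiens) for antiproliferative activity (on this read-out lower numbers stand for stronger inhibition and higher numbers for weaker inhibition), compound 1 gives 44700 nM, while compound 2 gives 158000 nM. Compound 2 thus has the higher of the two numbers, meaning the weaker inhibition, and the gap to compound 1 lies beyond the usual scatter.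

The next compound, compound 3 with structure `C/C=C/Cn1c(Cc2cc(OC)c(OC)c(OC)c2)nc2c(N)ncnc21`, keeps the core of compound 2 and changes only the chain: prop-1-en-1-yl in place of pentan-3-yl on a saturated chain carbon bound to an aromatic nitrogen. Both measured numbers are high, and the change trims the chain and adds a double bond, so the step is expected to be modest and toward stronger inhibition, about a 2.6-fold lower number from compound 2 to compound 3 (0.42 log units; beyond the scatter). Compound 3 is estimated at 60000 nM, within a range of 15000 nM to 250000 nM.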

Compound 3, half-maximal inhibitory concentration: 51300 nM
Compound 3: middle estimate off by 1.2-fold (0.07 log units), on the high side, within the range that was stated.
By their numbers in this assay, from the lowest: compounds 1 and 3 (each within the scatter of the next); then compound 2.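

Within the data shown here, compound 2 and compound 3 share the same core, so this is the first comparison here in which only the chain on the aromatic nitrogen changes. Compound 1 and compound 2 also differ on the core, so their gap could not be assigned to the chain alone. In this assay prop-1-en-1-yl in place of pentan-3-yl gives a 3.1-fold lower number from compound 2 to compound 3 (0.49 log units; beyond the scatter) and so shows that this position alone can shift the number by a modest step beyond the scatter, though no measurement shown here explains why.

This single change both shortens the chain and adds a double bond, and the compounds shown cannot separate those two differences. On these data alone, it also remains open how a saturated butyl chain or a longer chain ending in an amine would behave at this position.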